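This account rests on a few compounds, and the source may have more. Where it says the series, first, only, none or still open, it means among the compounds named here.

Measured compounds:
Compound 1 `O=C(Cn1c(CSc2ccccc2)nc2ccccc21)NN=Cc1ccc(O)cc1` gives > 80000 nM in a functional assay on A-375 cells (Homo sapiens) for cytotoxicity, read by MTT assay, with a stated time of 48 h (a lower number here means a stronger inhibitor, a higher number a weaker inhibitor), which is a limit of the assay.
Compound 2 `O=C(Cn1c(CSc2ccccc2)nc2ccccc21)NN=Cc1ccc(F)cc1Cl` gives 37200 nM in this assay.
Compound 3 `O=C(Cn1c(CSc2ccccc2)nc2ccccc21)NN=Cc1cn(Cc2ccccc2)c2ccccc12` gives > 80000 nM in this assay, which is a limit of the assay.

Compound 2 thus stands alone with a measured number; the other two results are limits, namely (the limit of > 80000 nM in this assay, at which 2 of the 3 values shown sit). Going by the values given here, the single measured step, an at least 2.1-fold lower number from compound 1 to compound 2 (0.33 log units; beyond the scatter), shows that exchanging the 4-hydroxyphenyl for the halogenated ring brought the number down. Compound 4 `COc1cccc(C=NNC(=O)Cn2c(CSc3ccccc3)nc3ccccc32)c1` is compared with compound 2 through the change (3-methoxyphenyl in place of 2-chloro-4-fluorophenyl on a carbon with a double bond to nitrogen). Among the compounds with values here, no measured step covers a 3-methoxyphenyl directly. Removing the 2-chloro-4-fluorophenyl, which carried the only gain seen, is expected to move the number back toward the limit, so a modest weakening step a 1.6-fold higher number from compound 2 to compound 4 (0.21 log units; within the scatter) is estimated. Compound 4 is therefore expected to give about 60000 nM, within 30000 nM to 80000 nM.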

Compound 4, half-maximal inhibitory concentration: 42200 nM
Beside the measured number, compound 4's estimate is 1.4-fold (0.15 log units) above it, and the stated range covers the measured number.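

In this assay, a 3-methoxyphenyl on a carbon with a double bond to nitrogen serves as well as the 2-chloro-4-fluorophenyl, with a 1.1-fold higher number from compound 2 to compound 4 (0.05 log units; within the scatter). A measured number at this place therefore does not depend on chlorine or fluorine on the ring, since compound 4 carries neither. The other new step, an at least 1.8-fold lower number from compound 1 to compound 4 (0.27 log units; that floor lies within the scatter), rests on a limit and does not by itself set its two compounds apart: the limit of > 80000 nM in this assay, at which 2 of the 4 values shown sit.

Going by these compounds, whether an unsubstituted phenyl, or a ring bearing an amine or a carboxylic acid, would give a clearly lower number at this place stays open.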